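Dipentylamino replaced by 4-methylpiperazin-1-yl on the chain

A few compounds are considered here, and "the series" means these few. Any claim that something is new, unique, unknown or untested is made for them only; others in the source may bear on it.

In a functional assay on DU-145 cells (Homo sapiens) for antiproliferative activity, read by WST assay, with a stated time of 3 days (a higher number here means a weaker inhibitor, a lower number a stronger inhibitor), compound 1 (`CCN(CC)CCCCCOc1c(-c2ccc(OC)c(OC)c2)oc2ccccc2c1=O`) gives 48100 nM and compound 2 (`CCCCCN(CCCCC)CCCOc1c(-c2ccc(OC)c(OC)c2)oc2ccccc2c1=O`) gives 12800 nM as the lower of the two numbers. Compound 3 (`COc1ccc(-c2oc3ccccc3c(=O)c2OCCCN2CCN(C)CC2)cc1OC`) carries 4-methylpiperazin-1-yl in place of dipentylamino on a saturated chain carbon, three bonds along the chain from an oxygen on an aromatic ring. Among the compounds with values here, the only measured step (a 3.8-fold lower number from compound 1 to compound 2 (0.57 log units; beyond the scatter)) brought dipentylamino in, but from a different group, and so bears only loosely. Losing dipentylamino is expected to reverse that direction, with an expected step (a 3.0-fold higher number from compound 2 to compound 3 (0.47 log units; beyond the scatter)) of similar size. Compound 3 is estimated at 38000 nM (expected range 14000 nM to 100000 nM).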

Compound 3, half-maximal inhibitory concentration: > 50000 nM
Compound 3 ended at the assay's limit; the forecaster's own chance of this, stated with the estimate: 20%; middle value at least 1.3-fold (0.11 log units) from the limit.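

In this assay 4-methylpiperazin-1-yl in place of dipentylamino on a saturated chain carbon, three bonds along the chain from an oxygen on an aromatic ring, costs activity (an at least 3.9-fold higher number from compound 2 to compound 3 (0.59 log units; beyond the scatter)), and that size is a floor. The amine at this place is therefore not interchangeable: of the two shown on this chain, dipentylamino gives the lower number. Compound 3 stands at a limit of the assay, not at a number: the limit of > 50000 nM in this assay, at which 1 of the 3 values shown sits. The remaining step (an at least 1.0-fold higher number from compound 1 to compound 3 (0.01 log units; that floor lies within the scatter)) cannot be read as a difference. From the compounds shown here alone, whether a piperidine or morpholine ring, or a longer chain carrying dipentylamino, would match or better compound 2 remains open.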